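From Cyclopropyl to Cyclopentyl on a Carbonyl Carbon

The compounds below may be only part of what the source reports. "The series", "measured", "known", "first", "only" and "open" are said of these compounds alone.

Measured in an in vitro ADME assay on microsomes from liver (Homo sapiens) for metabolic stability, tested at 1 uM; on this read-out lower numbers stand for a shorter-lived compound and higher numbers for a longer-lived compound:
compound 1 `CC(C)[C@]1(C(=O)N2C[C@@H]3C[C@H]2CN3C(=O)CC(C)(C)C)CC[C@@H](NC2CCOCC2)C1`: > 2 h
compound 2 `CCC(=O)N1C[C@@H]2C[C@H]1CN2C(=O)[C@@]1(C(C)C)CC[C@@H](NC2CCOCC2)C1`: > 2 h
compound 3 `CC(C)[C@]1(C(=O)N2C[C@@H]3C[C@H]2CN3C(=O)C2CC2)CC[C@@H](NC2CCOCC2)C1`: > 2 h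

Each entry is a limit of the assay and not a number. Compound 3 gives > 2 h, which is such a limit. All three compounds stand at the same point: the limit of > 2 h in this assay, at which 3 of the 3 values shown sit.

Compound 4 `CC(C)[C@]1(C(=O)N2C[C@@H]3C[C@H]2CN3C(=O)C2CCCC2)CC[C@@H](NC2CCOCC2)C1` has cyclopentyl in place of cyclopropyl on a carbonyl carbon. Two measured changes at this carbonyl carbon bear on it: a step that the two limits leave unreadable from compound 2 to compound 3 and a step that the two limits leave unreadable from compound 1 to compound 3. Neither has a readable size, so no step beyond the scatter, and no direction, is expected in this assay. The expected change is a step that the limit leaves unreadable from compound 3 to compound 4. The estimated half-life of compound 4 is 2.5 h, with an expected range from 1.2 h to 6 h.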

Compound 4, half-life: > 2 h
Compound 4 gave a limit, no number; the forecaster's own chance of this, stated with the estimate: 65%; the middle value lies beyond the limit too.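

In this assay compound 4 gives > 2 h, a limit and not a number. For the compounds shown here, no step among compound 1, compound 2, compound 3 and compound 4 can be read. Going by these compounds, whether the group on the carbonyl carbon changes the half-life at all stays open.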